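A few compounds are considered here, and "the series" means these few. Any claim that something is new, unique, unknown or untested is made for them only; others in the source may bear on it.

Within the data shown here, the two compounds measured so far share one core and differ only in the small group on the aromatic ring. Compound 1 `CCOc1cc(/C=C2\SC(=O)NC2=O)ccc1OCN1C(=O)c2ccccc2C1=O` carries an ethoxy group there, and in an assay on isolated protein for inhibition of Alpha glucosidase (Homo sapiens), read by spectrophotometry, with stated times of 15 min and 30 min (a lower number here means a stronger inhibitor, a higher number a weaker inhibitor), compound 1 gives 29300 nM. Among the measured compounds shown here, that is the only real number in the set. Compound 2 `O=C1NC(=O)/C(=C/c2cc(Cl)ccc2OCN2C(=O)c3ccccc3C2=O)S1` carries a chloro group at a different place on the ring, and in this assay compound 2 gives only > 100000 nM, which is a limit of the assay rather than a measured number. So compound 1 stands as the sole measured value, with the other entry sitting at the limit of > 100000 nM in this assay, at which 1 of the 2 values shown sits.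

Compound 3 `O=C1NC(=O)/C(=C/c2ccc(OCN3C(=O)c4ccccc4C3=O)c(Cl)c2)S1` is not yet measured. It differs from compound 1 by chloro in place of ethoxy on an aromatic carbon, in words: chloro in place of ethoxy on an aromatic carbon. For the measured compounds named here, there is no measured step between two compounds that makes exactly this exchange, so the size of the change in this assay cannot be read from the data. Given that the other chloro-bearing compound, compound 2, reached only a limit, compound 3 is expected to be weaker than compound 1, with a step of a 2.0-fold higher number from compound 1 to compound 3 (0.31 log units; beyond the scatter). Compound 3 is therefore estimated at 60000 nM, within a range from 25000 nM to 150000 nM.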

Compound 3, half-maximal inhibitory concentration: 21000 nM
Estimate against measurement, compound 3: 2.9-fold (0.46 log units) above; measured number below the stated range.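

At this place on the aromatic ring, ortho to a large group, ethoxy and chloro read alike in this assay: the exchange gives a 1.4-fold lower number from compound 1 to compound 3 (0.14 log units; within the scatter). The group that leaves has 3 heavy atoms and 1 hydrogen-bond acceptor, the group that enters has 1 heavy atom and no hydrogen-bond acceptor, and yet this measurement cannot tell compound 1 and compound 3 apart, so a chloro group on the ring does not by itself rule out a measurable number. Compound 2 also carries a chloro group, at a different place on the ring, and its entry is a limit of the assay rather than a number: the limit of > 100000 nM in this assay, at which 1 of the 3 values shown sits.

The compounds shown leave open whether a hydroxyl, an amine or a longer chain such as butoxy at this same position would read any differently from ethoxy and chloro. They also leave open how much the arrangement of the groups on the ring matters, as compound 2 offers no number to set beside that of compound 3.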